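The source may report more compounds than this note shows. Statements on the series, on what has been measured and on what is new or still open speak of the compounds shown alone.

In an ADME assay on MDBK cells (Bos taurus) for cytotoxicity (on this read-out lower numbers stand for higher toxicity in this test and higher numbers for lower toxicity in this test), compound 2 `COc1ccc(Cn2ccc3nc(-c4ccccc4)nc-3c2)cc1` gives only a limit of the assay, > 100000 nM. Compound 1 `COc1cccc(Cn2ccc3nc(-c4ccccc4)nc-3c2)c1` likewise gives only a limit, > 100000 nM. Among the compounds with values here, the single measured step, a step that the two limits leave unreadable from compound 1 to compound 2, cannot be sized since both values sit at the limit of > 100000 nM in this assay, at which 2 of the 2 values shown sit. Compound 3 `FC(F)(F)Oc1ccc(Cn2ccc3nc(-c4ccccc4)nc-3c2)cc1` differs from compound 2 by trifluoromethyl in place of methyl on an oxygen on an aromatic ring. Within the data shown here, no measured step bears on this change, so no shift beyond the scatter is foreseen, and the expected step of a number no higher from compound 2 to compound 3 (the limit leaves the size open) is small. Compound 3 is therefore estimated at 100000 nM, between 50000 nM and 200000 nM, most probably reported again as a limit.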

Compound 3, half-maximal cytotoxic concentration: 66000 nM
Compound 3: middle estimate off by 1.5-fold (0.18 log units), on the high side; low and high end bracket the measured number.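

Unlike the earlier compounds, compound 3 gives a true number in this assay, so this series can be read in this test and not only as a limit. Trifluoromethyl in place of methyl on the oxygen gives an at least 1.5-fold lower number from compound 2 to compound 3 (0.18 log units; that floor lies within the scatter), so this change cannot yet be called a real shift. The earlier compounds offered no such reading: the limit of > 100000 nM in this assay, at which 2 of the 3 values shown sit.

From the compounds shown here alone, the true number for compound 2 stays open, and with it the full size of this step. Also open, going by these compounds, is what an amine or a carboxylic acid would do in place of the trifluoromethoxy group.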